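Chlorophenyl sulfone series: ortho versus para chlorine

This account rests on a few compounds, and the source may have more. Where it says the series, first, only, none or still open, it means among the compounds named here.

Within the data shown here, compound 1 `CN1CCN(c2ccc3[nH]nc(S(=O)(=O)c4ccccc4Cl)c3c2)CC1` gives 101 nM in a functional assay on HeLa cells for antagonist activity at 5-hydroxytryptamine receptor 6 (Homo sapiens) (on this read-out higher numbers stand for weaker inhibition and lower numbers for stronger inhibition), the higher of the two numbers so far; compound 2 `CN1CCN(c2cccc3c(S(=O)(=O)c4cccc5ccccc45)n[nH]c23)CC1` gives 17 nM in this assay, and the gap between the two is beyond the scatter. Compound 3 `CN1CCN(c2ccc3[nH]nc(S(=O)(=O)c4ccc(Cl)cc4)c3c2)CC1` differs from compound 1 only by 4-chlorophenyl in place of 2-chlorophenyl on a sulfonyl sulfur. Among the measured compounds shown here, no measured pair shows this change, so the step from compound 1 to compound 3 in this assay is expected to be small, in no clear direction, and most likely within the scatter, as a 1.3-fold lower number from compound 1 to compound 3 (0.10 log units; within the scatter). Compound 3 is accordingly estimated at 80 nM, with a range from 25 nM to 250 nM.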

Compound 3, half-maximal inhibitory concentration: 108 nM
Compound 3: the middle estimate sits 1.4-fold (0.13 log units) below what was measured; the measured number falls inside the stated range.
By their numbers in this assay, from the lowest: compound 2; then compounds 1 and 3 (each within the scatter of the next).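

In this assay, 4-chlorophenyl in place of 2-chlorophenyl on a sulfonyl sulfur gives a 1.1-fold higher number from compound 1 to compound 3 (0.03 log units; within the scatter), so the two chlorophenyl groups cannot be told apart on this read-out. Among these compounds, this pair is the first direct reading of this swap, and it holds for the core of compound 1 only. No measured evidence bears on this result.

Open, going by these compounds, is whether a methoxy group or an amine in place of the chlorine would read the same on this core. Compound 2 differs from compound 1 in more than one place, so its number cannot be tied to any single group.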